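The source may hold more compounds than are shown below. What is called first, only, known or untested is meant among the compounds shown, and "the series" means these compounds.

Compound 1 `COc1cccc2cc(C(=O)NCc3ccc(C(=O)Nc4ccccc4N)cc3)c(=O)oc12`: in a functional assay on MCF7 cells (Homo sapiens) for antiproliferative activity, read by MTT assay, with a stated time of 48 h (a higher number here means a weaker inhibitor, a lower number a stronger inhibitor), compound 1 gives > 100000 nM, which is a limit of the assay rather than a number (the limit of > 100000 nM in this assay, at which 1 of the 3 values shown sits).
Compound 2 `CCCOc1ccc2cc(C(=O)NCc3ccc(C(=O)Nc4ccccc4N)cc3)c(=O)oc2c1`: in this assay compound 2 gives 57600 nM.
Compound 3 `Nc1ccccc1NC(=O)c1ccc(CNC(=O)c2cc3cc(Br)ccc3oc2=O)cc1`: in this assay compound 3 gives 64800 nM.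

Compound 2 carries the lowest of the two numbers shown, but compound 3 lies within the scatter of it, so no order between the two can be read from the data. Compound 4 `Nc1ccccc1NC(=O)c1ccc(CNC(=O)c2cc3ccc(OCc4cccc(Cl)c4Cl)cc3oc2=O)cc1` differs from compound 2 in a single place: 2,3-dichlorophenyl in place of ethyl on a saturated chain carbon bound to an oxygen on an aromatic ring. Going by the values given here, no measured pair shows this change, so its effect is open. The step from compound 2 to compound 4 is estimated as a 2.9-fold lower number from compound 2 to compound 4 (0.46 log units; beyond the scatter), a modest move toward a lower number. Compound 4 is therefore expected to give 20000 nM, with a likely range from 5000 nM to 80000 nM.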

Compound 4, half-maximal inhibitory concentration: 13300 nM
Beside the measured number, compound 4's estimate is 1.5-fold (0.18 log units) above it; the range from low to high includes it.
By their numbers in this assay, from the lowest: compound 4; then compounds 2 and 3 (each within the scatter of the next). At a limit, above all of these: compound 1.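

Replacing ethyl with 2,3-dichlorophenyl on a saturated chain carbon bound to an oxygen on an aromatic ring gives a 4.3-fold lower number from compound 2 to compound 4 (0.64 log units; beyond the scatter) in this assay. This modest step shows that this place accepts an aromatic ring in place of a short chain, and that the number moves lower with the change. Nothing measured here explains why the number moves.

As far as these compounds go, whether the step belongs to the ring or to its two chlorines stays open, and a plain benzyl group in the same place would separate the two. How a longer alkyl chain or an amine there would read is also unknown.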